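The source may report more compounds than this note shows. Statements on the series, on what has been measured and on what is new or still open speak of the compounds shown alone.

All three measured compounds were tested in a functional assay on HepG2 cells (Homo sapiens) for antiproliferative activity, read by CCK-8 assay, with a stated time of 72 h, tested at 8 uM (a higher number here means a stronger effect of the compound at the concentration tested, a lower number a weaker effect), and the numbers are:

- compound 1, `CC(C)n1cnc2c(Nc3ccccc3)nc(NCOCc3ccc(/C=C/C(=O)Nc4ccccc4N)cc3)nc21`, gives 40.8%
- compound 2, `CC(C)n1cnc2c(Nc3cccc(Cl)c3)nc(NCOCc3ccc(/C=C/C(=O)Nc4ccccc4N)cc3)nc21`, gives 49.9%
- compound 3, `CCCCn1cnc2c(Nc3ccccc3)nc(NCOCc3ccc(C(=O)Nc4ccccc4N)cc3)nc21`, gives 70.7%

Compound 1 and compound 2 share a core and differ in one place only: chloro in place of hydrogen on an aromatic carbon. That change moved the read-out by a number 9.1 percentage points higher from compound 1 to compound 2 (within the scatter), which means the two numbers cannot be told apart with confidence. Compound 3 has a different core, carrying a butyl chain and a shorter linker in front of the aminoanilide; the difference between the two cores is not broken down here, and compound 3 has the highest of the three numbers, with both compound 1 and compound 2 lying beyond the scatter below it.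

Compound 4, `CCCCn1cnc2c(Nc3cccc(Cl)c3)nc(NCOCc3ccc(C(=O)Nc4ccccc4N)cc3)nc21`, has not yet been measured. It stands to compound 3 as compound 2 stands to compound 1: chloro in place of hydrogen on an aromatic carbon. The place is described in the same words for both pairs, so this is the same change made on a second core. Among the measured compounds shown here, the only guide to its effect is the step seen between compound 1 and compound 2, which was small and within the scatter. On that basis the step from compound 3 to compound 4 is expected to be about a number 5.3 percentage points higher from compound 3 to compound 4 (within the scatter), small and possibly not distinguishable from no change, because the same change gave a number 9.1 percentage points higher from compound 1 to compound 2 (within the scatter) on the other core. Compound 4 is therefore estimated to give about 76% in this assay, most likely between 62% and 90%.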

Compound 4, a percentage reported as inhibition, at one concentration (the size of the read-out at that concentration, not a potency): 63.1%
Beside the measured number, compound 4's estimate is 12.9 percentage points above it, and the stated range covers the measured number.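

On the core of compound 3, chloro in place of hydrogen on an aromatic carbon gave a number 7.6 percentage points lower from compound 3 to compound 4 (within the scatter) in this assay, so this step, like the earlier one on the other core, cannot on its own be told apart from no change. Set side by side, however, the two steps do not agree, which shows that in this series the change cannot simply be carried from one core to the other as a fixed amount: the same change on two cores in this assay, a number 9.1 percentage points higher (within the scatter) from compound 1 to compound 2 and a number 7.6 percentage points lower (within the scatter) from compound 3 to compound 4, 16.7 percentage points apart, beyond the scatter of two such steps What this does not show is the reason for the mismatch, and it does not show how the change would behave on any further core: the two cores differ in more than one place, and each core offers only a single pair of compounds.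

The compounds shown leave open whether the mismatch follows the butyl chain or the linker in front of the aminoanilide, and how a longer chain such as hexyl would fit into the picture. Also open, as far as these compounds go, is how a group other than chloro on the phenyl ring, such as methoxy or an amine, would behave on each of the two cores.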